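A few compounds are considered here, and "the series" means these few. Any claim that something is new, unique, unknown or untested is made for them only; others in the source may bear on it.

Measured compounds in a physicochemical assay for lipophilicity; on this read-out lower numbers stand for lower lipophilicity and higher numbers for higher lipophilicity
Compound 1 (`C[C@H]1CC[C@@H]2[C@@H](OC(=O)[C@]23CC(c2ccccc2Br)=NO3)[C@]2(C)C(=O)C=C[C@@]12O`) gives 2.22
Compound 2 (`C[C@H]1CC[C@@H]2[C@@H](OC(=O)[C@]23CC(c2ccccc2F)=NO3)[C@]2(C)C(=O)C=C[C@@]12O`) gives 1.58

Among the compounds with values here, of the two numbers, compound 2 holds the lower, 1.58 and compound 1 is its only neighbour. Compound 3 (`C[C@H]1CC[C@@H]2[C@@H](OC(=O)[C@]23CC(c2ccccc2Cl)=NO3)[C@]2(C)C(=O)C=C[C@@]12O`) differs from compound 2 in one place (chloro in place of fluoro on an aromatic carbon): chloro in place of fluoro on an aromatic carbon, ortho to a large group, so that 2-fluorophenyl becomes 2-chlorophenyl. One measured change bears on this, a number 0.64 log units lower from compound 1 to compound 2 (beyond the scatter) on replacing bromo with fluoro, a modest step. The new change runs the other way, and chloro falls between fluoro and bromo among the halogens, so a rise smaller than that step is expected. The expected move is a number 0.47 log units higher from compound 2 to compound 3 (beyond the scatter) in this assay and would lie beyond the scatter. For compound 3 the estimated value is 2.05 within an expected range from 1.8 to 2.3.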

Compound 3, partition coefficient: 2.09
The estimate for compound 3 lay 0.04 log units below the measured number, and the stated range covers the measured number.
By their numbers in this assay, from the lowest: compound 2; then compounds 3 and 1 (each within the scatter of the next).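

In this assay the 2-chlorophenyl does not sit midway in the halogen series: a number 0.51 log units higher from compound 2 to compound 3 (beyond the scatter) is a step beyond the scatter, whereas a number 0.13 log units lower from compound 1 to compound 3 (within the scatter) stays within it. On this aromatic carbon, ortho to a large group, the read-out therefore separates fluoro from chloro and from bromo but does not separate chloro from bromo. Within the data shown here, the single step known earlier could not show this, as it spanned only the two outer halogens and gave no sign of how the change divides between them.

The compounds shown carry only halogens at this place, so it remains open whether a methoxy group, a nitrile or an amine would give a value near that of fluoro or near those of chloro and bromo. Nothing available here accounts for this grouping of the three values.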